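Aryl urea sulfonamides: expectation for compound 3

The source may report more compounds than this note shows. Statements on the series, on what has been measured and on what is new or still open speak of the compounds shown alone.

Measured so far:
- compound 1 `COc1ccc(NC(=O)Nc2ccc(C)c(S(=O)(=O)N(C)C)c2)cc1` gives 1700 nM in an assay on HEK293 cells for activation of Kir3.1/Kir3.2 (Homo sapiens), read by fluorescence and thallium flux, with a stated time of 4 min; on this read-out lower numbers stand for an effect already at smaller amounts and higher numbers for an effect only at larger amounts of compound
- compound 2 `Cc1ccc(NC(=O)Nc2cccc(F)c2)cc1S(=O)(=O)N(C)C` gives 1100 nM in this assay

Compound 2 holds the lower of the two numbers in this assay, but the only step shown, a 1.5-fold lower number from compound 1 to compound 2 (0.19 log units; within the scatter), lies within the scatter, so the two compounds cannot be ordered. Compound 3 `Cc1ccc(NC(=O)Nc2ccccc2Cl)cc1S(=O)(=O)N(C)C` differs from compound 2 by 2-chlorophenyl in place of 3-fluorophenyl on an amide-type nitrogen. Among the measured compounds shown here, no measured step covers this particular swap; the one step available, a 1.5-fold lower number from compound 1 to compound 2 (0.19 log units; within the scatter), shows an aryl exchange on the same nitrogen staying within the scatter. No step beyond the scatter is therefore expected in this assay. Compound 3 is estimated at 1300 nM (range 450 nM to 3800 nM), an expected 1.2-fold higher number from compound 2 to compound 3 (0.07 log units; within the scatter).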

Compound 3, half-maximal effective concentration: 2700 nM
Estimate against measurement, compound 3: 2.1-fold (0.32 log units) below, and the stated range covers the measured number.
By their numbers in this assay, from the lowest: compounds 2, 1 and 3 (each within the scatter of the next, the first and the last beyond it).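

In this assay, among the compounds shown here, the change to 2-chlorophenyl from 3-fluorophenyl gives a 2.5-fold higher number from compound 2 to compound 3 (0.39 log units; beyond the scatter) and is the only step on this amide-type nitrogen that lies beyond the scatter. The same group in place of 4-methoxyphenyl gives a 1.6-fold higher number from compound 1 to compound 3 (0.20 log units; within the scatter) and stays within the scatter, so among these three compounds the number responds to one aryl exchange at this position but not to the others. No measurement at hand accounts for the difference.

Open: whether the step follows the chlorine or its place on the ring, which 3-chlorophenyl and 2-fluorophenyl would separate. Also open, as far as these compounds go, is how a non-aryl group on this nitrogen, such as an amine-bearing chain or a carboxylic acid, would read.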